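Swapping a phenylethynyl arm for ethoxy on a fused core

This account rests on a few compounds, and the source may have more. Where it says the series, first, only, none or still open, it means among the compounds named here.

Measured compounds in a physicochemical assay for lipophilicity, measured as octanol-water partition; a lower number here means a more polar compound, a higher number a more lipophilic compound:
compound 1, `CCN1C(=O)c2c(nc(Cc3ccccc3)n2Cc2ccc(Cl)cc2)N2C1=N[C@@H]1CCC[C@@H]12`, 6.03
compound 2, `CCN1C(=O)c2c(nc(C#Cc3ccccc3)n2Cc2ccc(Cl)cc2)N2C1=N[C@@H]1CCC[C@@H]12`, 6.19
compound 3, `CCN1C(=O)c2c(nc(C#Cc3ccccc3)n2Cc2ccc(OC)cc2)N2C1=N[C@@H]1CCC[C@@H]12`, 5.5

All three share one core and differ only at two points. Compound 3 stands lowest of the three numbers in this assay: compound 1 is nearer to it, compound 2 furthest. Both gaps lie beyond the scatter.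

Compound 4, `CCOc1nc2c(n1Cc1ccc(OC)cc1)C(=O)N(CC)C1=N[C@@H]3CCC[C@@H]3N12`, has not yet been measured in this assay. It differs from compound 3 in one place: ethoxy in place of 2-phenylethynyl on an aromatic carbon.

Among the compounds with values here, no measured step covers this exact exchange. Two steps give a sense of scale. a number 0.16 log units higher from compound 1 to compound 2 (within the scatter) shows that reshaping the carbon arm while keeping the phenyl did little. a number 0.69 log units lower from compound 2 to compound 3 (beyond the scatter) shows that a single exchange of chloro for methoxy on the benzyl ring already moved the number by a modest amount. Here eight carbon atoms including a whole aromatic ring leave and a short ethoxy with one oxygen enters, a far larger change than either measured step.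

The number for compound 4 in this assay is therefore expected to fall well below that of compound 3, with an estimated step of a number 1.80 log units lower from compound 3 to compound 4 (beyond the scatter). Compound 4 is estimated at 3.7, with a range from 3 to 4.4.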

Compound 4, partition coefficient: 4.1
Compound 4: middle estimate off by 0.40 log units, on the low side; the range from low to high includes it.
By their numbers in this assay, from the lowest: compound 4; then compound 3; then compounds 1 and 2 (each within the scatter of the next).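

In this assay, putting ethoxy in place of 2-phenylethynyl on this aromatic carbon of the five-membered ring gives a number 1.40 log units lower from compound 3 to compound 4 (beyond the scatter), a larger step than any seen before at either point of change. Within the data shown here, the only earlier change at this position, a number 0.16 log units higher from compound 1 to compound 2 (within the scatter), kept the phenyl ring in the arm, so it could not show that the number here can move this far once that ring and the triple bond leave and a short arm bearing one oxygen enters. Nothing measured here explains the size of this step.

This single exchange changes the arm's size, removes its aromatic ring and adds an oxygen all at once, so the compounds shown cannot separate these changes: a propyl chain would bring a short arm without oxygen, while a phenoxy group would keep the aromatic ring and bring an oxygen. Also open, going by these compounds, is how an amine at this position would read in this assay, and whether a similar step would appear with a 4-chlorobenzyl group in place of the 4-methoxybenzyl group.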